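The compounds below may be only part of what the source reports. "The series", "measured", "known", "first", "only" and "open" are said of these compounds alone.

Working notes on the series. Compound 1 `CCCc1cc(N)c2cc(NC(=O)/C=C/c3ccc(Cl)cc3)ccc2n1` and compound 2 `Nc1cc(-c2ccccc2)nc2ccc(NC(=O)/C=C/c3ccc(C(F)(F)F)cc3)cc12` have been measured in a functional assay on HEK293 cells for activation of melanin-concentrating hormone receptor 1 (Homo sapiens), read by inositol phosphate accumulation; a lower number here means that less compound is needed, a higher number that more compound is needed for the effect. Compound 1 gives 96 nM in this assay, the lower of the two numbers. Compound 2 gives 6600 nM in this assay, a gap from compound 1 that is beyond the scatter. Compound 3 `CCCc1cc(N)c2cc(NC(=O)/C=C/c3ccc(Cl)c(Cl)c3)ccc2n1` has not yet been measured. It differs from compound 1 by chloro in place of hydrogen on an aromatic carbon. Among the measured compounds shown here, no pair of measured compounds shows this kind of change, so nothing fixes its size or direction. Compound 3 is expected to give about 80 nM in this assay, within 30 nM to 250 nM, which would be an estimated step of a 1.2-fold lower number from compound 1 to compound 3 (0.08 log units; within the scatter) and not clearly beyond the scatter.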

Compound 3, half-maximal effective concentration: 990 nM
Estimate against measurement, compound 3: 12-fold (1.09 log units) below; measured number above the stated range.
By their numbers in this assay, from the lowest: compound 1; then compound 3; then compound 2.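

In this assay, among the compounds shown here, the change from 4-chlorophenyl to 3,4-dichlorophenyl gives a 10-fold higher number from compound 1 to compound 3 (1.01 log units; beyond the scatter) and is the first step measured on this ring. It shows that a single added chloro, ortho to a chloro group and meta to a large group, is enough to move the number beyond the scatter, and that the move is towards more compound being needed. Nothing measured on these compounds accounts for the step.

Open, from the compounds shown here alone, is whether fluoro, methoxy or an amine in the same place would move the number as chloro does. Also open, going by these compounds, is whether the same step would appear with the phenyl of compound 2 in place of the propyl chain.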